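This account rests on a few compounds, and the source may have more. Where it says the series, first, only, none or still open, it means among the compounds named here.

Compound 1 `Cn1ccnc1NC(=O)c1cccc(Nc2ncc(F)c(Nc3ccc(F)cc3)n2)c1` gives 14600 nM in a functional assay on KB cells (Homo sapiens) for antiproliferative activity, read by sulforhodamine B assay, with a stated time of 3 days; a lower number here means a stronger inhibitor of growth, a higher number a weaker inhibitor of growth.
Compound 2 `COc1ccc(N2CCN(C)CC2)cc1Nc1ncc(F)c(Nc2ccc(F)cc2)n1` gives 960 nM in this assay.

Of these two, compound 1 stands as the weaker inhibitor of growth: in this assay compound 1 gives a higher number than compound 2, a gap beyond the usual scatter. Compound 3 `O=C(Nc1ccc(C(F)(F)F)cc1)c1cccc(Nc2ncc(F)c(Nc3ccc(F)cc3)n2)c1` is not yet measured. It is built from compound 1 by a single change, (4-(trifluoromethyl)phenyl in place of 1-methyl-1H-imidazol-2-yl on an amide-type nitrogen). Among the compounds with values here, no measured pair shows a step of this kind, so the direction rests on expectation alone; a moderate move toward a lower number is expected, a 4.9-fold lower number from compound 1 to compound 3 (0.69 log units; beyond the scatter). Compound 3 is therefore estimated at 3000 nM, within a range from 800 nM to 12000 nM.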

Compound 3, concentration for 50% growth inhibition: > 10000 nM
Compound 3: no number, only a limit (the forecaster's own chance of this, stated with the estimate: 5%); at least 3.3-fold (0.52 log units) between middle value and limit.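

In this assay compound 3 gives > 10000 nM, a limit and not a number, so the step from compound 1 to compound 3 cannot be read. On these data alone, whether 4-(trifluoromethyl)phenyl in place of 1-methyl-1H-imidazol-2-yl strengthens or weakens growth inhibition remains open.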